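Swapping a bromophenyl for a pyridyl on a shared core

A few compounds are considered here, and "the series" means these few. Any claim that something is new, unique, unknown or untested is made for them only; others in the source may bear on it.

Measured so far:
compound 1 `Cc1noc(-c2nc(C)c3c(c2N)C(=O)N(Cc2ccc(-n4cccn4)cc2)C3=O)n1` — < 5000 nM
compound 2 `Cc1noc(-c2nc(C)c3c(c2N)C(=O)N(Cc2ccc(Br)cc2)C3=O)n1` — < 5000 nM

In a physicochemical assay for solubility, using the shake flask method, in simulated intestinal fluid, measured as kinetic solubility, with a stated time of 2 h, at 25 degrees C, at pH 6.5 (on this read-out higher numbers stand for higher solubility and lower numbers for lower solubility), compound 1 gives only a limit, < 5000 nM. Compound 2 likewise gives only a limit in this assay, < 5000 nM. Both values sit at the limit of < 5000 nM in this assay, at which 2 of the 2 values shown sit, so the step that the two limits leave unreadable from compound 1 to compound 2 cannot be read. Compound 3 `Cc1noc(-c2nc(C)c3c(c2N)C(=O)N(Cc2ccncc2)C3=O)n1` differs from compound 2 by pyridin-4-yl in place of 4-bromophenyl on a saturated chain carbon bound to an amide-type nitrogen in a ring. For the measured compounds named here, no measured step resembles this change, and the two limits give no size to work from, so the direction and size of the step are open. Compound 3 is estimated at 15000 nM, between 3000 nM and 80000 nM, a step of an at least 3.0-fold higher number from compound 2 to compound 3 (0.47 log units; beyond the scatter) that is an estimate only.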

Compound 3, solubility: 26400 nM
Beside the measured number, compound 3's estimate is 1.8-fold (0.25 log units) below it; low and high end bracket the measured number.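

In this assay, for the compounds shown here, compound 3 is the first compound here to give a number and not a limit, so a change at this position on the saturated chain carbon can now be sized. Moving from 4-bromophenyl to pyridin-4-yl gives an at least 5.2-fold higher number from compound 2 to compound 3 (0.72 log units; beyond the scatter). Only a minimum size can be given for this step, and the earlier step cannot be read: the limit of < 5000 nM in this assay, at which 2 of the 3 values shown sit.

A plain phenyl group in this place would help to separate losing the bromine from gaining the ring nitrogen. As far as these compounds go, how a morpholine or a carboxylic acid would behave here also remains open.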